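The source may report more compounds than this note shows. Statements on the series, on what has been measured and on what is new or still open speak of the compounds shown alone.

Measured so far:
- compound 1 `CC1(C)[C@H]2CC[C@]1(C)N(Cc1cn(-c3ccccc3C#N)nn1)C(=O)C2`: 140 nM
- compound 2 `COc1ccccc1-n1cc(CN2C(=O)C[C@@H]3CC[C@@]2(C)C3(C)C)nn1`: 70 nM

In a functional assay on LoVo cells (Homo sapiens) for inhibition, read by MTT assay, with a stated time of 24 h (on this read-out higher numbers stand for weaker inhibition and lower numbers for stronger inhibition), compound 2 gives 70 nM. It has only compound 1 for comparison, and the two values lie within the usual scatter of each other, so neither stands apart.

Compound 3 `CC1(C)[C@H]2CC[C@]1(C)N(Cc1cn(-c3ccc(Br)cc3)nn1)C(=O)C2` shares the core of compound 2 but carries 4-bromophenyl in place of 2-methoxyphenyl on an aromatic nitrogen.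

Among the compounds with values here, only one measured step bears on this, a swap of methoxy for cyano on the aromatic ring: a 2.0-fold lower number from compound 1 to compound 2 (0.30 log units; within the scatter). Within the data shown here, that step stays within the scatter, although it is a single example, and no measured compound carries bromine. No clear shift in either direction is therefore expected in this assay. The expected step is a 1.4-fold higher number from compound 2 to compound 3 (0.15 log units; within the scatter). Compound 3 is estimated at 100 nM, with an expected range of 30 nM to 350 nM.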

Compound 3, half-maximal inhibitory concentration: 60 nM
Compound 3: the middle estimate sits 1.7-fold (0.22 log units) above what was measured, and the stated range covers the measured number.
By their numbers in this assay, from the lowest: compounds 3, 2 and 1 (each within the scatter of the next, the first and the last beyond it).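

In this assay, the step from the 2-methoxyphenyl to the 4-bromophenyl gives a 1.2-fold lower number from compound 2 to compound 3 (0.07 log units; within the scatter) and so shows that this position on the aromatic nitrogen can take a different group, at a different place on the phenyl ring, with no clear change in the number. Compared with the 2-cyanophenyl, the 4-bromophenyl gives a 2.3-fold lower number from compound 1 to compound 3 (0.37 log units; beyond the scatter) and this is the first step here to pass beyond the scatter, though only modestly. In both steps the group and its place on the phenyl ring change together, so the two effects cannot be told apart. Going by these compounds, whether an amine or a carboxylic acid on the phenyl ring would keep the number in this range remains open. Nothing measured here accounts for these differences.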